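One Stereocentre Inverted: From Compound 3 to Compound 4

This account rests on a few compounds, and the source may have more. Where it says the series, first, only, none or still open, it means among the compounds named here.

In a functional assay on A549 cells (Homo sapiens) for cytotoxicity, read by MTT assay, with a stated time of 48 h (on this read-out lower numbers stand for stronger inhibition and higher numbers for weaker inhibition), compound 1 (`COc1cc([C@@H]2C[C@]2(CO)C(=O)Nc2ccccc2Cl)cc(OC)c1OC`) gives 4400 nM, compound 2 (`CCOC(=O)[C@@]1(C(=O)Nc2ccccc2Cl)C[C@@H]1c1cc(OC)c(OC)c(OC)c1`) gives 29000 nM, and compound 3 (`COc1cc([C@H]2C[C@]2(CO)C(=O)Nc2ccccc2Cl)cc(OC)c1OC`) gives 36700 nM. Compound 3 thus stands level with compound 2, within the scatter, and clearly apart from compound 1. The next structure is compound 4 (`COc1cc([C@H]2C[C@@]2(CO)C(=O)Nc2ccccc2Cl)cc(OC)c1OC`), and the change leading to it is purely one of drawn configuration: the two compounds have the same atoms and bonds and differ only in configuration as drawn: 1 of 2 stereo elements differ; a stereocentre at a saturated ring carbon is drawn S in compound 3 and R in compound 4.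

Going by the values given here, only one measured step bears on this change: an 8.3-fold higher number from compound 1 to compound 3 (0.92 log units; beyond the scatter). The sole structural basis for that step is the fact that compounds 1 and 3 differ only in the configuration as drawn, so configuration alone can move the read-out beyond the scatter in this small set. That step does not fix a direction for the new change, but compound 3 at 36700 nM leaves more room downward, so a modest move toward a lower number is expected. The expected change is a 2.0-fold lower number from compound 3 to compound 4 (0.31 log units; beyond the scatter). The estimate for compound 4 is 18000 nM, with an expected range of 4500 nM to 50000 nM.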

Compound 4, half-maximal inhibitory concentration: > 100000 nM
Compound 4: only a limit was reported; the forecaster's own chance of this, stated with the estimate: 10%; at least 5.5-fold (0.74 log units) between middle value and limit.
By their numbers in this assay, from the lowest: compound 1; then compounds 2 and 3 (each within the scatter of the next). At a limit, above all of these: compound 4.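

In this assay compound 4 gives > 100000 nM, which is a limit of the assay and not a number. The earlier compounds shown here showed the effect of inverting only one stereocentre; here the other one is inverted, and this too moves the read-out beyond the scatter, with an at least 2.7-fold higher number from compound 3 to compound 4 (0.43 log units; beyond the scatter) and, with hydroxymethyl in place of ethoxycarbonyl, an at least 3.4-fold higher number from compound 2 to compound 4 (0.53 log units; beyond the scatter). The mirror-image pair gives an at least 22-fold higher number from compound 1 to compound 4 (1.35 log units; beyond the scatter) and so shows that the two configurations of this hydroxymethyl compound are far apart on this read-out: the fact that compounds 1 and 4 differ only in the configuration as drawn.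

The compounds shown leave open how a carboxylic acid or an amine would behave in place of the hydroxymethyl on that ring carbon. They also leave open whether ethoxycarbonyl follows the same order across the configurations.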